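From isopropoxy to 2-methoxyethoxy on the shared core

This account rests on a few compounds, and the source may have more. Where it says the series, first, only, none or still open, it means among the compounds named here.

Compound 1 `CC(C)c1ccc2c(c1)[n+]([O-])c(NCCN(C)C)n[n+]2[O-]`, compound 2 `COc1ccc2c(c1)[n+]([O-])c(NCCN(C)C)n[n+]2[O-]` and compound 3 `CC(C)Oc1ccc2c(c1)[n+]([O-])c(NCCN(C)C)n[n+]2[O-]` differ in one group on a shared core. In a physicochemical assay for solubility, in the presence of a further agent that is not named here (a higher number here means a more soluble compound, a lower number a less soluble compound), compound 1 gives 42000000 nM and compound 2 gives 46000000 nM. Compound 3 reads > 51000000 nM, which is a limit and not a number.

Compound 4 `COCCOc1ccc2c(c1)[n+]([O-])c(NCCN(C)C)n[n+]2[O-]` follows from compound 3 by 2-methoxyethyl in place of isopropyl on an oxygen on an aromatic ring. The closest measured step, an at least 1.1-fold higher number from compound 2 to compound 3 (0.04 log units; that floor lies within the scatter), changes the group on the same oxygen. The other two are a 1.1-fold higher number from compound 1 to compound 2 (0.04 log units; within the scatter) and an at least 1.2-fold higher number from compound 1 to compound 3 (0.08 log units; that floor lies within the scatter). None of the three goes beyond the scatter, so no step beyond the scatter is expected in this assay. The estimated step is a step that the limit leaves unreadable from compound 3 to compound 4. Compound 4 is expected at 55000000 nM, with an estimated range of 35000000 nM to 90000000 nM.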

Compound 4, solubility: 43000000 nM
The estimate for compound 4 lay 1.3-fold (0.11 log units) above the measured number, within the range that was stated.
By their numbers in this assay, from the lowest: compounds 1, 4 and 2 (each within the scatter of the next). At a limit, above all of these: compound 3.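

In this assay, for the compounds shown here, the steps of a 1.1-fold lower number from compound 2 to compound 4 (0.03 log units; within the scatter) and of a 1.0-fold higher number from compound 1 to compound 4 (0.01 log units; within the scatter) show that 2-methoxyethoxy, the first group with an oxygen inside its chain, stays level with the smaller groups on this aromatic carbon. The reading for compound 3 is a limit, so the step of an at least 1.1-fold lower number from compound 3 to compound 4 (0.07 log units; that floor lies within the scatter) gives only a floor and does not place these two compounds. Going by these compounds, whether an amine or a carboxylic acid in the chain on this oxygen would bring a step beyond the scatter stays open.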